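The compounds below may be only part of what the source reports. "The series", "measured", "known", "first", "only" and "open" are said of these compounds alone.

Measured compounds:
- Compound 1 `COc1ccc(-c2ccc(OCc3cc(C(=O)NS(=O)(=O)c4ccccc4)oc3C)cc2)c(C)c1`: 21 nM
- Compound 3 `COc1ccc(-c2ccc(OCc3cc(C(=O)NS(=O)(=O)c4c(C)noc4C)oc3C)cc2)c(C)c1`: 24 nM
- Compound 2 `Cc1oc(C(=O)O)cc1COc1ccc(-c2ccc(CO)cc2)cc1`: 3000 nM

In an assay on cells for displacement of a labelled ligand from prostaglandin E2 receptor EP4 subtype (Homo sapiens), read by scintillation counting (on this read-out higher numbers stand for weaker inhibition and lower numbers for stronger inhibition), compound 1 holds the lowest number of the three, with compound 3 close by and compound 2 far away. Within the data shown here, the one single-point change measured, a 1.1-fold higher number from compound 1 to compound 3 (0.06 log units; within the scatter), lies within the scatter. Compound 4 `Cc1oc(C(=O)NS(=O)(=O)c2ccccc2)cc1COc1ccc(-c2ccc(OC(F)F)cc2)cc1` differs from compound 1 in the outer ring: 4-(difluoromethoxy)phenyl in place of 4-methoxy-2-methylphenyl on an aromatic carbon. Among the measured compounds shown here, no measured pair touches this part of the molecule, so the measured steps give no direct guide to its size or direction. Given that, the change from compound 1 to compound 4 is expected to be small, and a number near that of compound 1, leaning slightly higher, is estimated: a 1.9-fold higher number from compound 1 to compound 4 (0.28 log units; within the scatter), giving compound 4 an expected value of about 40 nM, with a range from 12 nM to 150 nM.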

Compound 4, inhibition constant in the prostaglandin E2 receptor EP4 subtype assay: 1.3 nM
The estimate for compound 4 lay 31-fold (1.49 log units) above the measured number; measured number outside the range, below it.
By their numbers in the prostaglandin E2 receptor EP4 subtype assay, from the lowest: compound 4; then compounds 1 and 3 (each within the scatter of the next); then compound 2.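

Among these compounds, in the prostaglandin E2 receptor EP4 subtype assay, the outer ring proves to be a sensitive position: 4-(difluoromethoxy)phenyl in place of 4-methoxy-2-methylphenyl gives a 16-fold lower number from compound 1 to compound 4 (1.21 log units; beyond the scatter), whereas the one earlier single-point change, on the sulfonyl sulfur, stayed within the scatter. The same change comes with a loss in a physicochemical assay for solubility, in phosphate buffer, with a stated time of 24 h, at pH 7.4; on this read-out lower numbers stand for lower solubility and higher numbers for higher solubility: the measured solubility of compound 1, 20 ug/mL, and of compound 4, < 0.6 ug/mL, an at least 33-fold lower number (1.52 log units; beyond the scatter) In the physicochemical assay compound 1 gives 20 ug/mL. In the physicochemical assay compound 4 gives < 0.6 ug/mL, which is a limit of the assay, not a number: the limit of < 0.6 ug/mL in the physicochemical assay, at which 1 of the 2 values shown sits.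

The compounds shown do not separate the loss of the methyl from the swap of methoxy for difluoromethoxy. From the compounds shown here alone, whether an amine on the outer ring could keep the low binding number while regaining solubility remains open.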